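This account rests on a few compounds, and the source may have more. Where it says the series, first, only, none or still open, it means among the compounds named here.

Of the compounds shown here, two have so far been tested in a functional assay on the whole organism (blood, strain albino) with Mus musculus as the target, with stated times of 6 days and 4 h, at a dose of 0.4 mmol/kg by the oral route; a lower number here means less inhibition, a higher number more inhibition at the dose given (going by the name of the read-out). Compound 1 `Cc1cc(C(=O)O)nn1-c1ccc(S(=O)(=O)NC(=S)NC2CCCCC2)cc1` gives 1% there, the lowest of the two numbers, though its nearest neighbour lies within the usual scatter. That neighbour, compound 2 `Cc1cc(C)n(-c2ccc(S(=O)(=O)NC(=O)NC3CCCCC3)cc2)n1`, gives 10% in this assay, so no order between the two can be claimed. Compound 3 `CCCCNC(=O)NS(=O)(=O)c1ccc(-n2nc(C(=O)O)cc2C)cc1` has not yet been measured. Set against compound 1 it carries a group of 7 heavy atoms (5 carbon, 1 nitrogen, 1 oxygen; no ring) in place of a group of 9 heavy atoms (7 carbon, 1 nitrogen, 1 sulfur; one six-membered non-aromatic ring of carbon only), on a sulfonamide nitrogen. Within the data shown here, no step between measured compounds covers a change of this kind, and both measured values sit at the low end of the read-out, so the step of a number 4 percentage points higher from compound 1 to compound 3 (within the scatter) is expected to stay small and not to go beyond the scatter in either direction. Compound 3 is accordingly expected to give about 5% in this assay, with a range from -8% to 20%.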

Compound 3, a percentage reported as inhibition, in the whole organism at one dose (the size of the read-out at that dose, not a potency): 2%
Compound 3: middle estimate off by 3 percentage points, on the high side, within the range that was stated.
By their numbers in this assay, from the lowest: compounds 1, 3 and 2 (each within the scatter of the next).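

In this assay, the sulfonamide nitrogen proves open to a substantial exchange: butylcarbamoyl, with no ring, replaces a sulfur-bearing group with one six-membered non-aromatic ring of carbon only, and the result is a number 1 percentage points higher from compound 1 to compound 3 (within the scatter) in this read-out. Among these compounds, this position therefore gives the first comparison of two compounds that differ in one place, and the exchange does not separate them, as both stay at the low end of the read-out. No measurement shown offers an explanation for this outcome.

Because the ring and the sulfur leave together, the compounds shown do not tell the contribution of each apart. They also leave open how an octyl chain or a benzyl group on the same sulfonamide nitrogen would read in this assay, and whether either would lift the number above the scatter.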